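The source may hold more compounds than are shown below. What is called first, only, known or untested is meant among the compounds shown, and "the series" means these compounds.

Measured so far:
compound 1 `COc1cc(-c2nn(-c3cccc(NC(=O)c4cccc(C(F)(F)F)c4)c3)cc2-c2ccncc2)ccc1Cl` — 1020 nM
compound 2 `COc1cc(-c2nn(-c3cccc(NC(=O)Nc4cccc(C(F)(F)F)c4)c3)cc2-c2ccncc2)ccc1Cl` — 310 nM

In a functional assay on SF-295 cells (Homo sapiens) for inhibition, read by sulforhodamine B assay, with a stated time of 48 h (on this read-out higher numbers stand for weaker inhibition and lower numbers for stronger inhibition), compound 2 gives 310 nM, the lowest of the two numbers; the nearest is compound 1, which gives 1020 nM. Within the data shown here, the single measured step, a 3.3-fold lower number from compound 1 to compound 2 (0.52 log units; beyond the scatter), shows that putting an amino group between the carbonyl carbon and the trifluoromethyl-bearing ring went with a lower number. Compound 3 `COc1cc(-c2nn(-c3cccc(NC(=O)c4ccc(Cl)c(C(F)(F)F)c4)c3)cc2-c2ccncc2)ccc1Cl` removes that amino group again: 4-chloro-3-(trifluoromethyl)phenyl in place of (3-(trifluoromethyl)phenyl)amino on a carbonyl carbon. Among the measured compounds shown here, the ring now sits directly on the carbonyl carbon, as in compound 1, but it also carries a chlorine, and no measured pair shows what that chlorine does on its own. Because the direct attachment alone corresponded to the higher number of compound 1 (1020 nM), compound 3 is expected to land near compound 1. The step of a 2.6-fold higher number from compound 2 to compound 3 (0.41 log units; beyond the scatter) is therefore expected, toward a higher number. Compound 3 is estimated at 800 nM, within 300 nM to 2500 nM.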

Compound 3, half-maximal inhibitory concentration: 1380 nM
For compound 3 the middle estimate is 1.7-fold (0.24 log units) below the measured one, and the stated range covers the measured number.
By their numbers in this assay, from the lowest: compound 2; then compounds 1 and 3 (each within the scatter of the next).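

In this assay, the chloro in place of hydrogen on an aromatic carbon gives a 1.4-fold higher number from compound 1 to compound 3 (0.13 log units; within the scatter), so compound 1 and compound 3 cannot be told apart on this read-out. The other step, a 4.5-fold higher number from compound 2 to compound 3 (0.65 log units; beyond the scatter), shows that the number stays separated from that of compound 2 when the ring sits directly on the carbonyl carbon, with or without this chlorine. No measurement available here offers a reason for either step.

Going by these compounds, it remains open whether a chlorine on the ring of compound 2 would also leave the number unchanged. On these data alone, it is also open how a methylene group in place of the amino group on the carbonyl carbon, or a fluoro or methoxy group in place of the chloro, would read.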